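This account rests on a few compounds, and the source may have more. Where it says the series, first, only, none or still open, it means among the compounds named here.

Compound 3 `COc1cc2c(cc1OC)[C@@H](c1cc(OC)c(OC)c(OC)c1)[C@H](C(=O)N1CCCC1)C(/C=C/C(=O)c1ccc(C3CCCCC3)cc1)=C2` gives 12.3 ug/mL in a functional assay on KBVIN cells (Homo sapiens) for cytotoxicity, read by sulforhodamine B assay (a higher number here means a weaker inhibitor, a lower number a stronger inhibitor), which places it second highest among the three measured numbers. Its nearest neighbour is compound 1 `COC(=O)[C@H]1C(/C=C/C(=O)c2ccc([N+](=O)[O-])cc2)=Cc2cc(OC)c(OC)cc2[C@H]1c1cc(OC)c(OC)c(OC)c1`, which gives 23 ug/mL in this assay, a gap that lies within the scatter, so the two cannot be ordered. Compound 2 `COC(=O)[C@H]1C(/C=C/C(=O)c2ccc(O)cc2)=Cc2cc(OC)c(OC)cc2[C@H]1c1cc(OC)c(OC)c(OC)c1` gives 5.17 ug/mL in this assay, a gap from compound 3 that lies beyond the scatter.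

Compound 4 `COc1cc2c(cc1OC)[C@@H](c1cc(OC)c(OC)c(OC)c1)[C@H](C(=O)N1CCCC1)C(/C=C/C(=O)c1ccc(-c3ccccc3)cc1)=C2` differs from compound 3 in one place: phenyl in place of cyclohexyl on an aromatic carbon.

Among the measured compounds shown here, the single measured step, a 4.4-fold lower number from compound 1 to compound 2 (0.65 log units; beyond the scatter), concerns a hydroxy in place of a nitro on the other end of the shared core, not an exchange of a cyclohexyl for a phenyl, so it does not bear on the present change. For the measured compounds named here, no measured step speaks to the move from compound 3 to compound 4, and no step beyond the scatter is therefore expected, as a 1.0-fold lower number from compound 3 to compound 4 (0.01 log units; within the scatter) expresses. Compound 4 is estimated at 12 ug/mL in this assay, with a range from 4 ug/mL to 35 ug/mL.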

Compound 4, half-maximal inhibitory concentration: 16.9 ug/mL
Compound 4: the middle estimate sits 1.4-fold (0.15 log units) below what was measured, within the range that was stated.
By their numbers in this assay, from the lowest: compound 2; then compounds 3, 4 and 1 (each within the scatter of the next).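

Going from the 4-cyclohexylphenyl group to the 4-phenylphenyl group, this assay shows a 1.4-fold higher number from compound 3 to compound 4 (0.14 log units; within the scatter), so the two compounds cannot be ordered. Among the compounds shown here, this is the first measured step at this position, and it shows that a non-aromatic ring of carbon only and an aromatic ring of carbon only can be exchanged here without a difference that stands clear of repeated measurement. No available evidence bears on this result.

The compounds shown leave open whether an amine or a carboxylic acid on this ring, in place of the cyclohexyl or phenyl, would give a step beyond the scatter. They also leave open whether the exchange of cyclohexyl for phenyl would read the same on the core of compound 1.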